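The compounds below may be only part of what the source reports. "The series", "measured", "known", "first", "only" and "open" are said of these compounds alone.

For the measured compounds named here, in a functional assay on MCF7 cells (Homo sapiens) for antiproliferative activity, read by MTT assay, with a stated time of 48 h (on this read-out lower numbers stand for stronger inhibition and higher numbers for weaker inhibition), two compounds sharing one core have numbers so far. Compound 1 (`CC(C)=CCC[C@]1(C)/C=C/[C@@H](OC(=O)C=C(C)C)[C@](C)(O)/C=C/C(=O)/C(CN2CCCC2)=C\C1`) gives 220 nM, while compound 2 (`CC(C)=CCC[C@]1(C)/C=C/[C@@H](OC(=O)C=C(C)C)[C@](C)(O)/C=C/C(=O)/C(Cn2cc(CO)nn2)=C\C1`) gives 2930 nM, the higher of the two numbers and thus the weaker inhibition. The next compound to be measured is compound 3 (`CC(C)=CCC[C@]1(C)/C=C/[C@@H](OC(=O)C=C(C)C)[C@](C)(O)/C=C/C(=O)/C(C(=O)N(C(C)C)C(C)C)=C\C1`). The structural change is this: diisopropylcarbamoyl in place of (4-(hydroxymethyl)-1H-1,2,3-triazol-1-yl)methyl on a double-bonded ring carbon. In words, diisopropylcarbamoyl stands in place of (4-(hydroxymethyl)-1H-1,2,3-triazol-1-yl)methyl on a double-bonded ring carbon.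

Going by the values given here, only one measured step concerns the substituent at this carbon. It is large and beyond the scatter: a 13-fold higher number from compound 1 to compound 2 (1.12 log units; beyond the scatter), with 4-(hydroxymethyl)-1H-1,2,3-triazol-1-yl in place of pyrrolidin-1-yl on the saturated chain carbon. Among the compounds with values here, that step shows that changes in this substituent can shift the number considerably, but no measured compound carries a carbamoyl group, so it fixes neither the size nor the direction of the coming step with any confidence. A modest move towards a lower number, not clearly beyond the scatter, is expected, and the estimated step is a 1.6-fold lower number from compound 2 to compound 3 (0.21 log units; within the scatter). The estimate for compound 3 is 1800 nM, with an expected range from 400 nM to 7500 nM.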

Compound 3, half-maximal inhibitory concentration: 17200 nM
Compound 3: middle estimate off by 9.6-fold (0.98 log units), on the low side, and the stated range ends below it.
By their numbers in this assay, from the lowest: compound 1; then compound 2; then compound 3.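

In this assay, placing diisopropylcarbamoyl on the double-bonded ring carbon in place of (4-(hydroxymethyl)-1H-1,2,3-triazol-1-yl)methyl gives a 5.9-fold higher number from compound 2 to compound 3 (0.77 log units; beyond the scatter) and so moves the number upward, beyond the scatter. Set against the (pyrrolidin-1-yl)methyl group, the same diisopropylcarbamoyl group gives a 78-fold higher number from compound 1 to compound 3 (1.89 log units; beyond the scatter), which shows that the substituent at this carbon spans a wider range than the first pair revealed, with compound 1 still the lowest of the three. No measurement at hand bears on what lies behind these shifts.

On these data alone, the three groups differ in several features at once, so it stays open whether the higher number of compound 3 goes with the carbonyl on the ring carbon, with the two isopropyl groups or with the loss of the ring. A smaller amide such as dimethylcarbamoyl, pyrrolidin-1-ylcarbonyl as the direct amide counterpart of the group in compound 1, and an open-chain amine such as (dimethylamino)methyl would each bear on that question, and the compounds shown say nothing about how any of them would read.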